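Methoxy to hydroxy on the chlorophenyl ring

The source may report more compounds than this note shows. Statements on the series, on what has been measured and on what is new or still open speak of the compounds shown alone.

Among the measured compounds shown here, compound 2 `COc1cc(-c2nn(-c3cccc(NC(=O)Nc4cc(C(F)(F)F)cc(C(F)(F)F)c4)c3)cc2-c2ccncc2)ccc1Cl` gives 3710 nM in a functional assay on SK-MEL-2 cells (Homo sapiens) for inhibition, read by sulforhodamine B assay, with a stated time of 48 h (on this read-out lower numbers stand for higher toxicity in this test and higher numbers for lower toxicity in this test), and is the only compound in this set with a numerical reading. Compound 1 `O=C(Nc1cccc(-n2cc(-c3ccncc3)c(-c3ccc(Cl)c(O)c3)n2)c1)Nc1cccc(C(F)(F)F)c1` sits at a limit in this assay, > 32500 nM, so it contributes no number (the limit of > 32500 nM in this assay, at which 1 of the 2 values shown sits). For the measured compounds named here, compound 1 and compound 2 differ in more than one place, so their two values show only that the hydroxy-bearing compound reached the limit while the methoxy-bearing one did not.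

Compound 3 `O=C(Nc1cccc(-n2cc(-c3ccncc3)c(-c3ccc(Cl)c(O)c3)n2)c1)Nc1cc(C(F)(F)F)cc(C(F)(F)F)c1` is not yet measured. It differs from compound 2 by hydrogen in place of methyl on an oxygen on an aromatic ring, which gives the 4-chloro-3-hydroxyphenyl group that compound 1 also carries. Going by the values given here, no measured pair in this set isolates that change, so its size is unknown here. The expectation is a step towards lower toxicity of a 3.2-fold higher number from compound 2 to compound 3 (0.51 log units; beyond the scatter), somewhat beyond the scatter, with a real chance that only a limit is returned. Compound 3 is therefore estimated at 12000 nM in this assay, with a range from 3500 nM to 40000 nM.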

Compound 3, concentration lethal to 50% of the cells: 14100 nM
Beside the measured number, compound 3's estimate is 1.2-fold (0.07 log units) below it, and the stated range covers the measured number.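

In this assay, the methoxy to hydroxy change on the 4-chloro-3-methoxyphenyl group now has a size of its own, read on a matched pair with the rest of the structure held constant (a 3.8-fold higher number from compound 2 to compound 3 (0.58 log units; beyond the scatter)), and it runs towards lower toxicity in this test. With the 4-chloro-3-hydroxyphenyl group held constant, a second change appears at a different place, trifluoromethyl in place of hydrogen on an aromatic carbon, and it runs the other way, towards higher toxicity in this test (an at least 2.3-fold lower number from compound 1 to compound 3 (0.36 log units; beyond the scatter)). Compound 1 stands at a limit, so this second step is a bound and not a full size: the limit of > 32500 nM in this assay, at which 1 of the 3 values shown sits.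

As far as these compounds go, the oxygen carries only hydrogen or methyl in these compounds, so it remains open how an ethoxy group or an amine at that place would read in this assay. Among the compounds shown here, it also remains open whether the methoxy to hydroxy step keeps its size on a compound with one trifluoromethyl group, as no numerical pair with that group is available here.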